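The compounds below may be only part of what the source reports. "The series", "measured", "known", "first", "only" and "open" are said of these compounds alone.

Compound 1 `CNC(=O)c1cc(C(=O)NC2CC2)cn(Cc2ccc(F)cc2)c1=O` and compound 2 `CNC(=O)c1cc(C(=O)NC2CC2)cn(Cc2cccc(F)c2)c1=O` share a core and differ only in the fluorophenyl group on a saturated chain carbon bound to an aromatic nitrogen. Among the measured compounds shown here, in a physicochemical assay for lipophilicity, at pH 7.4 (on this read-out lower numbers stand for lower lipophilicity and higher numbers for higher lipophilicity), compound 1 reads 3.2 and compound 2 reads 3.2, so compound 2 stands level with its only measured neighbour. Compound 3 `CNC(=O)c1cc(C(=O)NC2CC2)cn(Cc2cccc3[nH]ccc23)c1=O` exchanges that group for a different one: 1H-indol-4-yl in place of 3-fluorophenyl on a saturated chain carbon bound to an aromatic nitrogen. Put simply, 1H-indol-4-yl comes in place of 3-fluorophenyl, adding a five-membered aromatic ring with 1 hetero atom and 1 hydrogen-bond donor. For the measured compounds named here, only one measured step bears on this change, no change at the digits printed from compound 1 to compound 2 (within the scatter), and it merely swaps 4-fluorophenyl for 3-fluorophenyl. Going by the values given here, no measurement yet shows what happens when the fluorophenyl group itself gives way to a two-ring group, so the evidence is thin and points in no firm direction. The expected outcome in this assay is a number 0.10 log units higher from compound 2 to compound 3 (within the scatter), a step not expected to rise beyond the scatter. For compound 3 the estimated value is 3.3, with an expected range of 2.8 to 3.8.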

Compound 3, distribution coefficient: 2.9
For compound 3 the middle estimate is 0.40 log units above the measured one, and the stated range covers the measured number.
By their numbers in this assay, from the lowest: compounds 3, 1 and 2 (each within the scatter of the next).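

In this assay, putting 1H-indol-4-yl in place of 3-fluorophenyl on a saturated chain carbon bound to an aromatic nitrogen gives a number 0.30 log units lower from compound 2 to compound 3 (within the scatter) when read against the first fluorinated partner, and putting it in place of 4-fluorophenyl gives a number 0.30 log units lower from compound 1 to compound 3 (within the scatter) at the same spot. The earlier pair only exchanged one fluorophenyl group for another, whereas these steps show that a much larger change, bringing in a five-membered aromatic ring with a hetero atom and a hydrogen-bond donor, still stays within the usual scatter of this read-out, so the three compounds cannot be put in a firm order. No measurement at hand offers a reason for these readings.

As far as these compounds go, it remains open whether an amine or a carboxylic acid on the ring, or a longer chain in place of the single saturated carbon, would carry the reading beyond the scatter. Also open, from the compounds shown here alone, is whether the hydrogen-bond donor of 1H-indol-4-yl plays any part in these readings, a question that 1-methyl-1H-indol-4-yl, with a methyl group on the ring nitrogen, could address.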